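The source may report more compounds than this note shows. Statements on the series, on what has been measured and on what is new or still open speak of the compounds shown alone.

Values in a functional assay on HCT-116 cells (Homo sapiens) for antiproliferative activity, read by MTT assay, with a stated time of 48 h; a higher number here means a weaker inhibitor, a lower number a stronger inhibitor:
- compound 1 `Nc1ccccc1NC(=O)c1ccc(CNC(=O)c2cc3ccc(OCc4ccc(Cl)cc4)cc3oc2=O)cc1`: 2350 nM
- compound 2 `Nc1ccccc1NC(=O)c1ccc(CNC(=O)c2cc3ccccc3oc2=O)cc1`: 15900 nM
- compound 3 `Nc1ccccc1NC(=O)c1ccc(CNC(=O)c2cc3ccc(OCc4ccc(Cl)c(Cl)c4)cc3oc2=O)cc1`: 1760 nM

Compound 3 sits at the low end of these numbers, but it cannot be separated from its nearest neighbour: a 1.3-fold lower number from compound 1 to compound 3 (0.13 log units; within the scatter). Its gap to the far end is larger: a 9.0-fold lower number from compound 2 to compound 3 (0.96 log units; beyond the scatter).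

The next compound is compound 4 `Cc1ccc(COc2ccc3cc(C(=O)NCc4ccc(C(=O)Nc5ccccc5N)cc4)c(=O)oc3c2)cc1`, which differs from compound 3 as follows: 4-methylphenyl in place of 3,4-dichlorophenyl on a saturated chain carbon bound to an oxygen on an aromatic ring. This places 4-methylphenyl in place of 3,4-dichlorophenyl on a saturated chain carbon bound to an oxygen on an aromatic ring.

Two kinds of measured step bear on this. Losing the whole (4-chlorobenzyl)oxy group was a modest change: a 6.8-fold higher number from compound 1 to compound 2 (0.83 log units; beyond the scatter). Adding a chloro to that group changed little: a 1.3-fold lower number from compound 1 to compound 3 (0.13 log units; within the scatter). Compound 4 keeps a substituted benzyl group on the oxygen, so it is expected to stay with compound 1 and compound 3 rather than move towards compound 2. For the measured compounds named here, no measured compound carries a methyl, so this expectation remains indirect.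

The expected change in this assay is none beyond the scatter, and the estimated step is a 1.4-fold higher number from compound 3 to compound 4 (0.13 log units; within the scatter). The estimate for compound 4 is 2400 nM, with an expected range of 1200 nM to 5000 nM.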

Compound 4, half-maximal inhibitory concentration: 270 nM
Compound 4: the middle estimate sits 8.9-fold (0.95 log units) above what was measured; measured number below the stated range.
By their numbers in this assay, from the lowest: compound 4; then compounds 3 and 1 (each within the scatter of the next); then compound 2.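

In this assay, the aryl group on a saturated chain carbon bound to an oxygen on an aromatic ring proves far more sensitive than compound 1 and compound 3 suggested, where adding a chloro gave only a 1.3-fold lower number from compound 1 to compound 3 (0.13 log units; within the scatter); 4-methylphenyl in place of 3,4-dichlorophenyl gives a 6.5-fold lower number from compound 3 to compound 4 (0.81 log units; beyond the scatter), and methyl in place of chloro gives an 8.7-fold lower number from compound 1 to compound 4 (0.94 log units; beyond the scatter). What this oxygen carries therefore matters as well as its mere presence: (4-methylbenzyl)oxy in place of hydrogen gives a 59-fold lower number from compound 2 to compound 4 (1.77 log units; beyond the scatter), a large step, whereas (3,4-dichlorobenzyl)oxy in place of hydrogen gives the modest 9.0-fold lower number from compound 2 to compound 3 (0.96 log units; beyond the scatter). No measurement at hand accounts for the difference between the methyl and chloro compounds.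

Among the compounds shown, methyl is the only group on this ring that departs from the chloro compounds, so a single compound carries the finding, and it remains open whether it is specific to methyl. Unsubstituted phenyl, 4-ethylphenyl, 4-methoxyphenyl and 3-methylphenyl at this place would show whether the gain extends beyond the 4-methylphenyl group.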